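The source may report more compounds than this note shows. Statements on the series, on what has been measured and on what is new or still open speak of the compounds shown alone.

In a functional assay on A-431 cells (Homo sapiens) for cytotoxicity, read by MTT assay, with a stated time of 48 h (on this read-out higher numbers stand for weaker inhibition and lower numbers for stronger inhibition), compound 2, whose structure is `CCCCCCCCCCCCCCNC(=O)[C@@H](NC(=O)c1cc2ccccc2n1C)[C@@H](C)O`, gives 13700 nM. Among the measured compounds shown here, that is the only number obtained so far in this assay; the one other result is a limit rather than a number. Compound 1, with the structure `CCCCCCCCCCCCNC(=O)[C@@H](NC(=O)/C=C/c1ccccc1)[C@@H](C)O`, reached only the limit of > 200000 nM in this assay, so that (the limit of > 200000 nM in this assay, at which 1 of the 2 values shown sits).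

Compound 3, with the structure `CCCCCCCCCCCCCCNC(=O)[C@@H](NC(=O)/C=C/c1ccccc1)[C@@H](C)O`, is still to be measured in this assay. It differs from compound 2 in one place: 2-phenylethenyl in place of 1-methyl-1H-indol-2-yl on a carbonyl carbon. For the measured compounds named here, no step between two measured compounds is available that would show the effect of this change directly, so the expectation rests on what the two results show. The step from compound 2 to compound 3 is expected to weaken inhibition well beyond the scatter, by an 8.8-fold higher number from compound 2 to compound 3 (0.94 log units; beyond the scatter). The direction of this expectation follows compound 1, which carries the same 2-phenylethenyl group on the carbonyl carbon and gave only the limit of > 200000 nM in this assay. For compound 3 the estimate in this assay is 120000 nM, within a range from 20000 nM to 500000 nM, with a real chance that only a limit is reported.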

Compound 3, half-maximal inhibitory concentration: 64900 nM
Compound 3: the middle estimate sits 1.8-fold (0.27 log units) above what was measured; the measured number falls inside the stated range.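

In this assay, the change on the carbonyl carbon now has a direct measure. With the chain of compound 2 kept, 2-phenylethenyl in place of 1-methyl-1H-indol-2-yl gives a 4.7-fold higher number from compound 2 to compound 3 (0.68 log units; beyond the scatter), so the 1-methyl-1H-indol-2-yl group is the better of the two at this position, though the loss is smaller than the earlier results alone suggested. The second step shows that the 2-phenylethenyl compounds also respond to the chain: ethyl in place of hydrogen on a saturated chain carbon gives an at least 3.0-fold lower number from compound 1 to compound 3 (0.48 log units; beyond the scatter), and this size is only a bound because compound 1 stands at a limit and not at a number: the limit of > 200000 nM in this assay, at which 1 of the 3 values shown sits.

The compounds shown carry the 1-methyl-1H-indol-2-yl group with one chain length only, so it remains open whether that group would respond to the chain in the same way. Also open, going by these compounds, is how a still longer chain would behave, or an amine or a carboxylic acid at the chain end.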